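Carboxymethyl for Methylsulfonyl: Cytotoxicity Expectation for Compound 3

The compounds below may be only part of what the source reports. "The series", "measured", "known", "first", "only" and "open" are said of these compounds alone.

compound 1 `CCOC(=O)CCCCCOc1cccc(CN(C(=O)c2ccc(-c3cccc(OCC)c3)cc2)C(C)C)c1`: > 22300 nM
compound 2 `CCOC(=O)CCCCCOc1cccc(CN(C(=O)c2ccc(-c3cccc(S(C)(=O)=O)c3)cc2)C(C)C)c1`: > 26000 nM

In an ADME assay on HEK293 cells (Homo sapiens) for cytotoxicity, read by CellTiter-Glo and resazurin assay, with a stated time of 72 h (on this read-out higher numbers stand for an effect only at larger amounts of compound and lower numbers for an effect already at smaller amounts), compound 1 returns only a limit, > 22300 nM. Compound 2 likewise gives only a limit, > 26000 nM. Going by the values given here, the single measured step, a step that the two limits leave unreadable from compound 1 to compound 2, is unreadable: both of its ends are limits. Compound 2 thus stands at a limit, with no number to rank it. Compound 3, `CCOC(=O)CCCCCOc1cccc(CN(C(=O)c2ccc(-c3cccc(CC(=O)O)c3)cc2)C(C)C)c1`, differs from compound 2 by carboxymethyl in place of methylsulfonyl on an aromatic carbon. Among the compounds with values here, no measured step bears on this change, so the step from compound 2 to compound 3 is expected to be a step that the limit leaves unreadable from compound 2 to compound 3, nothing readable beyond the scatter. Compound 3 is therefore estimated at 30000 nM, between 15000 nM and 100000 nM, most likely reported again only as a limit.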

Compound 3, half-maximal effective concentration: > 26000 nM
Compound 3 was reported as a limit; the forecaster's own chance of this, stated with the estimate: 80%; the middle value lies beyond the limit too.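

In this assay, going by these compounds alone, compound 3, like compound 1 and compound 2, returns only a limit, so no step among the three can be read. Where each compound's actual half-maximal concentration lies, and how the ethoxy, methylsulfonyl and carboxymethyl compounds rank, stays open.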